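Swapping phenyl for cyclohexyl in a potent platelet-activating factor antagonist

The source may report more compounds than this note shows. Statements on the series, on what has been measured and on what is new or still open speak of the compounds shown alone.

Compound 3 `COc1ccc(/C(=C/C=C/C(=O)N[C@H](C)CCCc2cccnc2)c2ccccc2)cc1` gives the lowest number of the three measured compounds in an assay (Canis lupus familiaris) for binding affinity to platelet-activating factor receptor (Homo sapiens), read by radioligand binding (on this read-out lower numbers stand for stronger inhibition and higher numbers for weaker inhibition), at 2 nM; compound 1 `CCCC/C(=C\C=C\C(=O)N[C@H](C)CCCc1cccnc1)c1ccc(OC)cc1` gives 14 nM and compound 2 `COc1ccc(/C(=C\C=C\C(=O)N[C@H](C)CCCc2cccnc2)C2CCCCC2)cc1` gives 20 nM. The unmeasured compound 4 `COc1ccc(/C(=C/C=C/C(=O)N[C@H](C)CCCc2cccnc2)C2CCCCC2)cc1` differs from compound 3 by cyclohexyl in place of phenyl on a double-bonded chain carbon bound to an aromatic carbon and a double-bonded chain carbon. Among the measured compounds shown here, the one step that bears on this position is a 7.0-fold lower number from compound 1 to compound 3 (0.85 log units; beyond the scatter), which shows that the phenyl matters. For the measured compounds named here, compound 2 also carries cyclohexyl at this position but differs elsewhere in the chain, so no direct step exists; its value simply sits above that of compound 3. A loss in this assay is therefore expected, of about a 5.0-fold higher number from compound 3 to compound 4 (0.70 log units; beyond the scatter). Compound 4 is estimated at 10 nM, within 3 nM to 40 nM.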

Compound 4, half-maximal inhibitory concentration: 20 nM
The estimate for compound 4 lay 2.0-fold (0.30 log units) below the measured number; the measured number falls inside the stated range.
By their numbers in this assay, from the lowest: compound 3; then compounds 1, 2 and 4 (each within the scatter of the next).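

In this assay, replacing phenyl with cyclohexyl gives a 10-fold higher number from compound 3 to compound 4 (1.00 log units; beyond the scatter), so this position does not accept every six-carbon ring equally. Cyclohexyl and butyl are not told apart here, with a 1.4-fold higher number from compound 1 to compound 4 (0.15 log units; within the scatter), which leaves phenyl alone among these groups in giving the lowest number. With cyclohexyl on this carbon, the drawn double-bond configuration shows no change at the digits printed from compound 2 to compound 4 (within the scatter), a clean comparison for this reason: the fact that compounds 2 and 4 differ only in the configuration as drawn

Still open, from the compounds shown here alone, is how a thiophene ring, a methyl or a longer chain would read on this carbon. Also open, going by these compounds, is whether the drawn double-bond configuration matters when phenyl sits there.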